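Working notes: cytotoxicity of the phenoxyalkyl thiourea series

The source may hold more compounds than are shown below. What is called first, only, known or untested is meant among the compounds shown, and "the series" means these compounds.

Measured compounds and their values in an ADME assay on Ava5 cells (Homo sapiens) for cytotoxicity; a higher number here means that more compound is tolerated, a lower number that less compound is tolerated:
Compound 1, `NC(=S)Nc1cccc(OCCCCCOc2ccccc2)c1`: compound 1 gives > 50000 nM, which is a limit of the assay.
Compound 2, `NC(=S)Nc1cccc(OCCCCCOc2ccc(Br)cc2)c1`: compound 2 gives 19000 nM.
Compound 3, `NC(=S)Nc1cccc(OCCCCCOc2ccc(-n3cccc3)cc2)c1`: compound 3 gives > 50000 nM, again a limit of the assay and not a number.

Compound 3 therefore stands only at a limit in this assay; two of the three values shown sit at that same limit (the limit of > 50000 nM in this assay, at which 2 of the 3 values shown sit). The steps between the measured compounds read as follows: an at least 2.6-fold lower number from compound 1 to compound 2 (0.42 log units; beyond the scatter); a step that the two limits leave unreadable from compound 1 to compound 3; an at least 2.6-fold higher number from compound 2 to compound 3 (0.42 log units; beyond the scatter).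

Compound 4 is `NC(=S)Nc1cccc(OCCCCCOc2ccc(-c3ccco3)cc2)c1`. Relative to compound 3 the change is furan-2-yl in place of 1H-pyrrol-1-yl on an aromatic carbon. Among the compounds with values here, the steps that bear on this are the two that exchange the group at the same position of the phenoxy ring: from compound 1 to compound 2 and from compound 2 to compound 3, each at least modest, while the step from compound 1 to compound 3 is unreadable between two limits. The entering furan-2-yl matches the leaving 1H-pyrrol-1-yl in the counts given above, so compound 4 is expected to stay at or near the limit, with an expected step of a number no higher from compound 3 to compound 4 (the limit leaves the size open) of no more than the scatter. The estimate for compound 4 in this assay is 50000 nM, with a range from 20000 nM to 120000 nM.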

Compound 4, half-maximal cytotoxic concentration: 11000 nM
The estimate for compound 4 lay 4.5-fold (0.66 log units) above the measured number; measured number outside the range, below it.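

In this assay, the position on an aromatic carbon para to a large group separates two groups that match in every count: 1H-pyrrol-1-yl and furan-2-yl are both five-membered aromatic rings with 5 heavy atoms and 1 hetero atom, yet furan-2-yl in place of 1H-pyrrol-1-yl gives an at least 4.5-fold lower number from compound 3 to compound 4 (0.65 log units; beyond the scatter). The earlier compounds shown here did not show that such counts fail to set the tolerated concentration at this place. Compound 4 instead reads with compound 2, which it cannot be told apart from, with a 1.7-fold lower number from compound 2 to compound 4 (0.24 log units; within the scatter), and against the unsubstituted compound the change is an at least 4.5-fold lower number from compound 1 to compound 4 (0.65 log units; beyond the scatter), so bromo and furan-2-yl go together here, while 1H-pyrrol-1-yl goes against any rule that a group at this place lowers the number.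

The values of compound 1 and compound 3 are each a limit of the assay and not a number, so the full size of the steps from them stays open and the step joining those two cannot be read: the limit of > 50000 nM in this assay, at which 2 of the 4 values shown sit.

Also open, from the compounds shown here alone, is whether thiophen-2-yl, an amine or a carboxylic acid at this same place would read with furan-2-yl and bromo or with 1H-pyrrol-1-yl.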